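The compounds below may be only part of what the source reports. "The series", "measured", "known", "first", "only" and "open" are said of these compounds alone.

The series shares one core, carried by compound 1 `Cc1nc(-c2ccccc2)c(C(=O)N2CCN(c3ccc(Cl)c(Cl)c3)CC2)o1`, compound 2 `Cc1nc(-c2ccccc2)c(C(=O)N2CCN(c3cccc(Cl)c3Cl)CC2)o1` and compound 3 `Cc1ccc(N2CCN(C(=O)c3oc(C)nc3-c3ccccc3)CC2)cc1`; the compounds differ only in the aryl group on an amine nitrogen in a ring. In a functional assay on HL-60 cells (Homo sapiens) for inhibition, read by MTT assay, with a stated time of 72 h (a lower number here means a stronger inhibitor, a higher number a weaker inhibitor), compound 1 gives 124 nM and compound 2 gives 133 nM, separated by a 1.1-fold higher number from compound 1 to compound 2 (0.03 log units; within the scatter). For compound 3 the reading is a limit of the assay, > 1000 nM, so only a bound is known; it sits at the limit of > 1000 nM in this assay, at which 1 of the 3 values shown sits. The steps of an at least 8.0-fold higher number from compound 1 to compound 3 (0.90 log units; beyond the scatter) and an at least 7.5-fold higher number from compound 2 to compound 3 (0.87 log units; beyond the scatter) both run toward weaker inhibition when 4-methylphenyl takes the place of either dichlorophenyl. Compound 4 `Cc1nc(-c2ccccc2)c(C(=O)N2CCN(c3cccc(C#N)c3)CC2)o1` is not yet measured; the change from compound 3 is 3-cyanophenyl in place of 4-methylphenyl on an amine nitrogen in a ring. Among the measured compounds shown here, no measured step covers 3-cyanophenyl. The two steps into compound 3 show only that leaving 4-methylphenyl for a dichlorophenyl regains much of the potency, and 3-cyanophenyl need not behave alike, so the expectation is loose. The estimate for compound 4 in this assay is 600 nM, with a range from 150 nM to 2500 nM, which means an expected step of an at least 1.6-fold lower number from compound 3 to compound 4 (0.22 log units; that floor lies within the scatter) from a starting point that is itself only a limit.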

Compound 4, half-maximal inhibitory concentration: 39.6 nM
Beside the measured number, compound 4's estimate is 15-fold (1.18 log units) above it; the measured number lies below the stated range.
By their numbers in this assay, from the lowest: compound 4; then compounds 1 and 2 (each within the scatter of the next). At a limit, above all of these: compound 3.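

In this assay, this position on the amine nitrogen in a ring can carry a group that outperforms both dichlorophenyl compounds, so two chlorines are not needed for potency here: 3-cyanophenyl gives (a 3.1-fold lower number from compound 1 to compound 4 (0.50 log units; beyond the scatter)) and (a 3.4-fold lower number from compound 2 to compound 4 (0.53 log units; beyond the scatter)). Against 4-methylphenyl, the change brings in a triple bond and a hydrogen-bond acceptor, and the number falls sharply (an at least 25-fold lower number from compound 3 to compound 4 (1.40 log units; beyond the scatter)). That step is only a bound, because compound 3 stands at a limit of the assay: the limit of > 1000 nM in this assay, at which 1 of the 4 values shown sits.

On these data alone, whether the nitrile itself is what matters remains open, since a single cyano-bearing aryl group cannot separate the group from its location on the ring. As far as these compounds go, how a carboxylic acid, a methoxy group or an unsubstituted phenyl would read at this position is also open.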